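This account rests on a few compounds, and the source may have more. Where it says the series, first, only, none or still open, it means among the compounds named here.

Measured compounds:
compound 1, `CNc1cc(-c2ccc3cnn(Cc4cc(OC)cc(OC)c4)c3c2)cn(C)c1=O`, 190 nM in a functional assay on MV4-11 cells (Homo sapiens) for antiproliferative activity, read by luminescence and CellTiter-Glo, with a stated time of 72 h; a lower number here means a stronger inhibitor, a higher number a weaker inhibitor
compound 2, `CNc1cc(-c2ccc3cnn(Cc4ccc(F)c([N+](=O)[O-])c4)c3c2)cn(C)c1=O`, 130 nM in this assay

Among the compounds with values here, compound 2 carries the lower of the two numbers, but its only neighbour is compound 1, and the step of a 1.5-fold lower number from compound 1 to compound 2 (0.16 log units; within the scatter) lies within the scatter, so the two compounds are not separated by the data. Within the data shown here, the one measured step exchanges one aryl group for another at the saturated chain carbon bound to an aromatic nitrogen and produces no change beyond the scatter.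

Compound 3, `CNc1cc(-c2ccc3cnn(CC4CCCCC4)c3c2)cn(C)c1=O`, differs from compound 2 as follows: cyclohexyl in place of 4-fluoro-3-nitrophenyl on a saturated chain carbon bound to an aromatic nitrogen. Among the measured compounds shown here, no measured step replaces an aromatic ring with a non-aromatic one at this position, so the measured step of a 1.5-fold lower number from compound 1 to compound 2 (0.16 log units; within the scatter) bears on it only loosely, showing that the group at this carbon can be varied without a change beyond the scatter. Compound 3 is therefore expected to stay near compound 2, with a step of a 1.5-fold higher number from compound 2 to compound 3 (0.19 log units; within the scatter) that is not expected to exceed the scatter. In this assay compound 3 is estimated at 200 nM, within a range from 80 nM to 500 nM.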

Compound 3, half-maximal inhibitory concentration: 2690 nM
Estimate against measurement, compound 3: 13-fold (1.13 log units) below, outside the stated range (above it).
By their numbers in this assay, from the lowest: compounds 2 and 1 (each within the scatter of the next); then compound 3.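

In this assay, the group on the saturated chain carbon bound to an aromatic nitrogen turns out to matter: placing cyclohexyl there gives a 21-fold higher number from compound 2 to compound 3 (1.32 log units; beyond the scatter) and also a 14-fold higher number from compound 1 to compound 3 (1.15 log units; beyond the scatter) in the same comparison with the other aryl compound. The earlier exchange of one aryl group for another had suggested a freely variable position, but that tolerance now holds only across the two substituted aromatic rings and does not extend to cyclohexyl, a non-aromatic ring of carbon only. The large step appears whichever of the two aryl groups leaves, so it does not depend on one particular set of ring substituents.

Nothing measured here accounts for this rise in the number. Between compound 2 and compound 3 the aromatic ring and its fluoro and nitro substituents leave together, so the compounds shown leave open whether an unsubstituted phenyl would stay with the aryl compounds, and whether a cyclohexyl carrying a hydroxyl or an amine would recover any of the difference.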